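Halogen swap at the ortho position of the benzylidene ring

A few compounds are considered here, and "the series" means these few. Any claim that something is new, unique, unknown or untested is made for them only; others in the source may bear on it.

Measured compounds:
compound 1 `C=CCOc1c(C)c(C)c2c(c1C)CCC(C)(COc1ccc(/C=C3\SC(=O)NC3=O)cc1)O2` gives 2% in a functional assay on MCF7 cells (Homo sapiens), tested at 7.5 uM; a lower number here means a stronger effect, a higher number a weaker effect of the compound at the concentration tested
compound 2 `CC(C)=CCOc1c(C)c(C)c2c(c1C)CCC(C)(COc1ccc(/C=C3\SC(=O)NC3=O)cc1F)O2` gives 64% in this assay
compound 3 `C=CCOc1c(C)c(C)c2c(c1C)CCC(C)(COc1ccc(/C=C3\SC(=O)NC3=O)cc1OCC)O2` gives 75% in this assay

Compound 2 stands second highest of the three numbers. Its nearest neighbour is compound 3, whose number lies higher, beyond the scatter; its furthest is compound 1, whose number lies far lower. For the measured compounds named here, the one single-point step among the measured compounds is a number 73 percentage points higher from compound 1 to compound 3 (beyond the scatter), a large rise on putting ethoxy in place of hydrogen on an aromatic carbon. Compound 2 and compound 1 differ in two places, so only their two values can be compared, and they point the same way: a substituent on that aromatic carbon goes with a much higher number.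

Compound 4 `CC(C)=CCOc1c(C)c(C)c2c(c1C)CCC(C)(COc1ccc(/C=C3\SC(=O)NC3=O)cc1Br)O2` differs from compound 2 by bromo in place of fluoro on an aromatic carbon. Going by the values given here, no measured step swaps one halogen for another, so nothing directly bears on this change. Both compounds carrying a group on that carbon, compound 2 and compound 3, give high numbers, and a bromo group keeps that carbon occupied. In this assay the step of a number 4 percentage points higher from compound 2 to compound 4 (within the scatter) is therefore expected to stay within the scatter. Compound 4 is estimated at 68%, with a range from 50% to 88%.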

Compound 4, a percentage reported as activity, at one concentration (the size of the read-out at that concentration, not a potency): 53%
For compound 4 the middle estimate is 15 percentage points above the measured one; the measured number falls inside the stated range.
By their numbers in this assay, from the lowest: compound 1; then compound 4; then compound 2; then compound 3.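

In this assay, for the compounds shown here, the halogen on this aromatic carbon is not interchangeable: a number 11 percentage points lower from compound 2 to compound 4 (beyond the scatter) is a change beyond the scatter, and it is the first measured exchange of one substituent for another at this carbon rather than of hydrogen for a group. A lower number marks a stronger effect, and bromo gives the stronger effect of this halogen pair. Occupying the carbon does not alone fix the read-out, although this modest step is much smaller than the large a number 73 percentage points higher from compound 1 to compound 3 (beyond the scatter) seen on a different ether chain. No measurement given here explains the step from fluoro to bromo.

As far as these compounds go, compounds 2 and 4 share one ether chain on the core and compounds 1 and 3 another, so the comparison of hydrogen with either halogen on a single chain remains open. Also open, from the compounds shown here alone, is where chloro, an amine, a carboxylic acid or a longer alkoxy chain on this carbon would fall relative to the fluoro and bromo compounds, and whether the order of the two halogens holds with the other ether chain.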